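The compounds below may be only part of what the source reports. "The series", "measured", "known", "first", "only" and "open" are said of these compounds alone.

Measured so far in an ADME assay on HCT-116 cells (Homo sapiens) for antiproliferative activity; a higher number here means a weaker inhibitor, a lower number a stronger inhibitor:
- compound 1 `COc1ccc(C(N)=O)cc1/C=C/c1ccccc1`: 36000 nM
- compound 2 `COc1ccc(C(N)=O)cc1/C=C/c1cccc(Cl)c1`: 15000 nM

Not yet measured: compound 3 `COc1ccc(C(N)=O)cc1/C=C/c1ccccc1OC(F)(F)F`.

For the measured compounds named here, compound 1 holds the higher of the two numbers in this assay, so the only measured neighbour lies on the stronger side of it. Compound 3 keeps the core of compound 1 and carries one change: trifluoromethoxy in place of hydrogen on an aromatic carbon. This is trifluoromethoxy in place of hydrogen on an aromatic carbon, ortho to a large group.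

Going by the values given here, one measured step bears on this change: a 2.4-fold lower number from compound 1 to compound 2 (0.38 log units; beyond the scatter). It is modest, and it is also a replacement of hydrogen on an aromatic carbon, but with chloro as the incoming group. Among the compounds with values here, no measured compound carries trifluoromethoxy, so this single step is a loose guide. A modest move to a lower number, of similar size, is expected in this assay, with no change beyond the scatter remaining possible. The expected step is a 2.1-fold lower number from compound 1 to compound 3 (0.33 log units; beyond the scatter). For compound 3 the estimated value is 17000 nM, with an expected range of 6000 nM to 40000 nM.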

Compound 3, half-maximal inhibitory concentration: 36000 nM
Beside the measured number, compound 3's estimate is 2.1-fold (0.33 log units) below it; the range from low to high includes it.
By their numbers in this assay, from the lowest: compound 2; then compounds 1 and 3 (each within the scatter of the next).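

In this assay, trifluoromethoxy on an aromatic carbon, ortho to a large group, gives no change at the digits printed from compound 1 to compound 3 (within the scatter), so this replacement of hydrogen adds 5 heavy atoms with no reading beyond the scatter in either direction. The earlier step, a 2.4-fold lower number from compound 1 to compound 2 (0.38 log units; beyond the scatter), therefore does not hold for every replacement of aromatic hydrogen in this series, and compound 3 is the case that goes against it. Nothing at hand accounts for the flat result with trifluoromethoxy.

The compounds shown do not separate the effect of the group from the effect of the place, as chloro and trifluoromethoxy are seen only on different carbons of the ring, so it remains unknown whether chloro would also give a flat step on this same carbon. Also open, on these data alone, is how a fluoro, an amine or a carboxylic acid on this carbon would read in this assay, and thus whether any group here can move the number beyond the scatter, in either direction, from that of compound 1.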